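Swapping the Sulfonyl Cap on the Ring Nitrogen

The compounds below may be only part of what the source reports. "The series", "measured", "known", "first", "only" and "open" are said of these compounds alone.

Measured so far:
- compound 1 `CN1CCN(c2ccc(Nc3ncc4nc(Nc5ccc(F)cc5)n([C@H]5CCCN(S(=O)(=O)C6CC6)C5)c4n3)cc2)CC1`, 8.6 nM
- compound 2 `CN1CCN(c2ccc(Nc3ncc4nc(Nc5ccc(F)cc5)n([C@H]5CCN(S(=O)(=O)C6CC6)C5)c4n3)cc2)CC1`, 7.5 nM

Both compounds were tested in a functional assay on HCC827 cells (Homo sapiens) for antiproliferative activity, read by MTT assay, with a stated time of 72 h; a lower number here means a stronger inhibitor, a higher number a weaker inhibitor. Compound 1 `CN1CCN(c2ccc(Nc3ncc4nc(Nc5ccc(F)cc5)n([C@H]5CCCN(S(=O)(=O)C6CC6)C5)c4n3)cc2)CC1` gives 8.6 nM, and compound 2 `CN1CCN(c2ccc(Nc3ncc4nc(Nc5ccc(F)cc5)n([C@H]5CCN(S(=O)(=O)C6CC6)C5)c4n3)cc2)CC1` gives 7.5 nM. Within the data shown here, compound 2 shows the lowest of the two numbers, but the only measured step, a 1.1-fold lower number from compound 1 to compound 2 (0.06 log units; within the scatter), lies within the scatter, so the two compounds cannot be told apart on these data.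

Compound 3 `CCOC(=O)CN1CC[C@H](n2c(Nc3ccc(F)cc3)nc3cnc(Nc4ccc(N5CCN(C)CC5)cc4)nc32)C1` is not yet measured. It differs from compound 2 in one place: (ethoxycarbonyl)methyl in place of cyclopropylsulfonyl on an amine nitrogen in a ring. Among the measured compounds shown here, the one measured step concerns the size of the ring that carries the cyclopropylsulfonyl group, not the group on the ring nitrogen itself, so nothing measured here bears directly on this change. With no guide, the expectation is a step of a 2.7-fold higher number from compound 2 to compound 3 (0.43 log units; beyond the scatter), leaning toward a weaker number but with wide uncertainty. Compound 3 is therefore expected to give about 20 nM in this assay, with a range from 5 nM to 100 nM.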

Compound 3, half-maximal inhibitory concentration: 1810 nM
The estimate for compound 3 lay 91-fold (1.96 log units) below the measured number, and the stated range ends below it.
By their numbers in this assay, from the lowest: compounds 2 and 1 (each within the scatter of the next); then compound 3.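

Among these compounds, at this position, the group on the ring nitrogen matters far more than the ring size, which made no readable difference in this assay with a 1.1-fold lower number from compound 1 to compound 2 (0.06 log units; within the scatter) as the only earlier step. Replacing cyclopropylsulfonyl with (ethoxycarbonyl)methyl gives a 240-fold higher number from compound 2 to compound 3 (2.38 log units; beyond the scatter) even though the two groups match in heavy-atom count and hydrogen-bond acceptor count and neither carries a net charge, so these counts alone do not capture what separates them here. The step that changes the ring as well, a 210-fold higher number from compound 1 to compound 3 (2.32 log units; beyond the scatter) and thus is also large, points the same way, but nothing measured here explains the loss.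

With only two groups on this nitrogen among the compounds shown, it remains open whether the sulfonyl is what supports the low numbers or the ester side chain is what raises them. A simple acetyl group, a methylsulfonyl group or a carboxylic acid in place of the ethyl ester would help separate those two readings.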